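A few compounds are considered here, and "the series" means these few. Any claim that something is new, unique, unknown or untested is made for them only; others in the source may bear on it.

Measured so far in an assay on isolated protein for inhibition of Polyunsaturated fatty acid 5-lipoxygenase (Homo sapiens), with stated times of 15 min and 10 min; on this read-out higher numbers stand for weaker inhibition and lower numbers for stronger inhibition:

- compound 1 `Oc1ccc(-c2csc(Nc3ccc(Cl)cc3)n2)cc1`: in this assay compound 1 gives 3100 nM
- compound 2 `Nc1ccc(-c2csc(Nc3ccc(O)cc3)n2)cc1`: in this assay compound 2 gives 4400 nM

Of these two numbers, that of compound 1 is the smaller, yet the gap to compound 2 lies within the usual scatter of repeated measurements, so the two compounds cannot be told apart on this read-out. Both share the same core, and they differ in two places at once, so no single change can be read off from them.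

Compound 3 `O=S(=O)(c1ccc(-c2csc(Nc3ccc(Cl)cc3)n2)cc1)N1CCOCC1` has not yet been measured in this assay. It differs from compound 1 in one place: (morpholin-4-yl)sulfonyl in place of hydroxy on an aromatic carbon, the (morpholin-4-yl)sulfonyl in place of hydroxy on an aromatic carbon. Within the data shown here, no measured pair shows this kind of change, so there is nothing in the data to lean on for its size or direction. With nothing speaking for a large effect, the step from compound 1 to compound 3 is expected to be a 1.1-fold higher number from compound 1 to compound 3 (0.05 log units; within the scatter), none beyond the scatter. The estimate for compound 3 in this assay is 3500 nM, with a range from 1200 nM to 10000 nM.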

Compound 3, half-maximal inhibitory concentration: > 30000 nM
Compound 3: a limit, no number; the forecaster's own chance of this, stated with the estimate: 10%; at least 8.5-fold (0.93 log units) between middle value and limit.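

In this assay compound 3 gives > 30000 nM, which is a limit of the assay and not a number. Putting (morpholin-4-yl)sulfonyl in place of hydroxy on this aromatic carbon, para to a large group, gives an at least 9.6-fold higher number from compound 1 to compound 3 (0.98 log units; beyond the scatter), so this is a lower bound on the change and its true size stays unknown, as it rests on a limit: the limit of > 30000 nM in this assay, at which 1 of the 3 values shown sits. This is the first single change shown at this position, and it shows that what sits here can matter, since the earlier pair differed in two places at once and stayed within the scatter.

This one change removes the hydroxy and brings in the sulfonyl and the morpholine ring together, so the compounds shown cannot tell whether the loss follows from the hydroxy leaving, from the sulfonyl, or from the ring. Going by these compounds, a methoxy, a primary sulfonamide or a carboxylic acid at the same place would help to separate these, and how each would fare in this assay remains open.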